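Dropping the chloro from compound 3

A few compounds are considered here, and "the series" means these few. Any claim that something is new, unique, unknown or untested is made for them only; others in the source may bear on it.

Among the measured compounds shown here, in an assay on isolated protein for inhibition of Thymidylate synthase (Homo sapiens) (a higher number here means a weaker inhibitor, a lower number a stronger inhibitor), compound 3 `N=c1scc(-c2ccc(Cl)cc2)n1CC(=O)N1CCOCC1` gives 3730 nM, the second highest of the three numbers measured so far. Compound 2 `N=c1scc(-c2ccc(Cl)cc2)n1CC(=O)N1CCN(c2ccccc2)CC1` gives 5090 nM, which lies within the scatter of compound 3, while compound 1 `CN1CCN(C(=O)Cn2c(-c3ccccc3)csc2=N)CC1` gives 1140 nM, a lower number beyond the scatter. Compound 4 `N=c1scc(-c2ccccc2)n1CC(=O)N1CCOCC1` has not been measured yet; its change from compound 3 is hydrogen in place of chloro on an aromatic carbon. For the measured compounds named here, compound 1 also carries a phenyl, but its amide part differs too, so no measured pair isolates this change alone. A small step is expected, if anything toward a lower number, because compound 1 with its phenyl gives 1140 nM. Compound 4 is therefore estimated at 2500 nM, with a range from 900 nM to 7000 nM. That corresponds to an expected step of a 1.5-fold lower number from compound 3 to compound 4 (0.17 log units; within the scatter).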

Compound 4, inhibition constant: 6220 nM
Compound 4: the middle estimate sits 2.5-fold (0.40 log units) below what was measured, and the stated range covers the measured number.
By their numbers in this assay, from the lowest: compound 1; then compounds 3, 2 and 4 (each within the scatter of the next).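

In this assay, going from 4-chlorophenyl to phenyl gives a 1.7-fold higher number from compound 3 to compound 4 (0.22 log units; within the scatter) and so the chloro on this aromatic carbon has no readable effect alongside the morpholin-4-yl amide. With the phenyl kept, the amide part gives the clearer difference: morpholin-4-yl in place of 4-methylpiperazin-1-yl gives a 5.5-fold higher number from compound 1 to compound 4 (0.74 log units; beyond the scatter) and this is beyond the scatter. No independent measurement here explains either result. Still open, going by these compounds, is whether a larger change at this spot, such as methoxy or a carboxylic acid, would move the number beyond the scatter. Also open, on these data alone, is whether chloro would behave alike with the 4-methylpiperazin-1-yl amide.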